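This account rests on a few compounds, and the source may have more. Where it says the series, first, only, none or still open, it means among the compounds named here.

Compound 1 `CCCNc1nc2c(NC3CCCC3)ncnc2n1[C@@H]1O[C@H](CO)[C@@H](O)[C@H]1O` gives 97 nM in an assay on cell membranes for binding affinity to Equilibrative nucleoside transporter 1 (Homo sapiens); a higher number here means a weaker inhibitor, a lower number a stronger inhibitor.
Compound 2 `CCCNc1nc2c(SCc3ccccc3)ncnc2n1C1O[C@H](CO)[C@@H](O)[C@H]1O` gives 5.3 nM in this assay.
Compound 3 `CCCCNc1nc2c(SCc3ccccc3)ncnc2n1C1O[C@H](CO)[C@@H](O)[C@H]1O` gives 5.4 nM in this assay.
Compound 4 `CCCCCNc1nc2c(SCc3ccccc3)ncnc2n1C1O[C@H](CO)[C@@H](O)[C@H]1O` has not yet been measured.

Among the three measured compounds, compound 2 stands at the lowest number. Compound 3 sits right beside it, the step being a 1.0-fold higher number from compound 2 to compound 3 (0.01 log units; within the scatter), so the two cannot be told apart. Compound 1 is far off, but it differs from compound 2 in more than one place, so its value only shows that both changes together take the number much higher.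

The move to compound 4 is ethyl in place of hydrogen on a saturated chain carbon, three bonds along the chain from a nitrogen on an aromatic ring. For the measured compounds named here, the one measured step that bears on this is the lengthening of the same chain by a single carbon, from compound 2 to compound 3, which gave a 1.0-fold higher number from compound 2 to compound 3 (0.01 log units; within the scatter). Adding one more carbon in the same direction has no measured counterpart here, but the only evidence is of a flat response, so the expected step in this assay, a 1.1-fold higher number from compound 2 to compound 4 (0.05 log units; within the scatter), is none beyond the scatter, in either direction. Compound 4 is therefore estimated at 6 nM, with a range from 2.5 nM to 15 nM.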

Compound 4, inhibition constant: 2.3 nM
For compound 4 the middle estimate is 2.6-fold (0.42 log units) above the measured one; the whole stated range lies above it.
By their numbers in this assay, from the lowest: compound 4; then compounds 2 and 3 (each within the scatter of the next); then compound 1.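

The chain on the nitrogen on an aromatic ring does not give the flat response that the first lengthening suggested: in this assay the change from propyl to pentyl gives a 2.3-fold lower number from compound 2 to compound 4 (0.36 log units; beyond the scatter) and counts as a modest gain. The single further carbon, from butyl to pentyl, gives a 2.3-fold lower number from compound 3 to compound 4 (0.37 log units; beyond the scatter) and is likewise beyond the scatter, while the change from propyl to butyl gave a 1.0-fold higher number from compound 2 to compound 3 (0.01 log units; within the scatter) and stayed within it. Across these three compounds, then, the response to chain length is not an even one, since the number moves only at the step to pentyl, and nothing available here explains this behaviour.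

A longer chain such as hexyl or heptyl could push the number lower still, hold it level or send it back up, and these compounds give no sign of which. On these data alone, it is equally open whether pentyl's effect depends on an unbranched chain of carbons, or whether a branched chain such as isopentyl, or a chain ending in an amine or a carboxylic acid, would fit at this place as well.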